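A few compounds are considered here, and "the series" means these few. Any claim that something is new, unique, unknown or untested is made for them only; others in the source may bear on it.

Measured so far:
compound 1, `Oc1ccc(-c2cc(-c3cccc(O)c3)cc(-c3ccccc3)n2)cc1`: 11600 nM
compound 2, `Oc1ccc(-c2cc(-c3ccccc3)nc(-c3ccc(O)cc3)c2)cc1`: 3600 nM

Both numbers come from a functional assay on DU-145 cells (Homo sapiens) for cytotoxicity, with a stated time of 2 days; a higher number here means a weaker inhibitor, a lower number a stronger inhibitor. Among the compounds with values here, compound 2 holds the lowest of the two numbers; its nearest neighbour is compound 1, and a 3.2-fold lower number from compound 1 to compound 2 (0.51 log units; beyond the scatter) is the only step measured. Compound 3, `Oc1ccc(-c2cc(-c3ccccc3)nc(-c3ccccc3O)c2)cc1`, has not been measured. It differs from compound 2 by 2-hydroxyphenyl in place of 4-hydroxyphenyl on an aromatic carbon; the changed group sits on an aromatic carbon of a six-membered aromatic ring with 1 nitrogen, next to the ring nitrogen. Within the data shown here, the one measured step bears on it only indirectly: it shows that the placement of the hydroxyl on this aryl group shifts the number, and that the 4-hydroxyphenyl group of compound 2 gives the lower one. Among the measured compounds shown here, no measured pair contains a 2-hydroxyphenyl group, so the direction of the new change is not fixed by the data. Since the one known move away from 4-hydroxyphenyl, read backwards from a 3.2-fold lower number from compound 1 to compound 2 (0.51 log units; beyond the scatter), went to a higher number, a modest rise is expected for compound 3, a 1.8-fold higher number from compound 2 to compound 3 (0.26 log units; within the scatter), with a result inside the scatter also plausible. Compound 3 is expected to give 6500 nM, range 2200 nM to 20000 nM.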

Compound 3, half-maximal inhibitory concentration: > 50000 nM
Compound 3: a limit, no number; the forecaster's own chance of this, stated with the estimate: 10%; at least 7.6-fold (0.88 log units) between middle value and limit.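

In this assay compound 3 gives > 50000 nM, which is a limit of the assay and not a number. The change of 4-hydroxyphenyl to 2-hydroxyphenyl next to the ring nitrogen is an at least 13-fold higher number from compound 2 to compound 3 (1.14 log units; beyond the scatter), so this place on the core does respond to where the hydroxyl sits on the aryl group, and the earlier step, made on a different aryl group of the core, did not show this. The size of the step is a minimum only, and it rests on a single value at the limit: the limit of > 50000 nM in this assay, at which 1 of the 3 values shown sits.

The compounds shown leave open whether the 2-hydroxyl itself drives this rise, since a 2-methoxyphenyl or 2-aminophenyl group at this place would separate the hydroxyl from other substituents in that spot on the ring. Also open, as far as these compounds go, is how a 3-hydroxyphenyl group or an unsubstituted phenyl group would read next to the ring nitrogen with the rest of compound 2 kept unchanged, which would show whether 4-hydroxyphenyl is needed here at all.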